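Diaryl series: chain ether to alcohol step

The source may report more compounds than this note shows. Statements on the series, on what has been measured and on what is new or still open speak of the compounds shown alone.

Measured compounds:
Compound 1 `COC[C@@H](C)[C@H](C)C(c1ccc(O)c(OC)c1)c1ccc(O)c(OC)c1` gives in a functional assay on HL-60 cells (Homo sapiens) for cytotoxicity, read by WST assay, with a stated time of 48 h (on this read-out lower numbers stand for stronger inhibition and higher numbers for weaker inhibition), a value of 73000 nM.
Compound 2 `COc1ccc(C(c2ccc(OC)c(OC)c2)[C@H](C)[C@@H](C)CO)cc1OC` gives in this assay a value of 47000 nM.
Compound 3 `COc1ccc(C(c2ccc(OC)c(OC)c2)[C@H](C)[C@H](C)CO)cc1OC` gives in this assay only a limit of the assay, > 100000 nM.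

Compound 1 holds the highest of the two numbers that are not limits; compound 2 sits nearest to it, within the scatter. For the measured compounds named here, the only step between compounds that differ in one place is an at least 2.1-fold higher number from compound 2 to compound 3 (0.32 log units; beyond the scatter); its size rests on the limit of > 100000 nM in this assay, at which 1 of the 3 values shown sits, and on (the fact that compounds 2 and 3 differ only in the configuration as drawn), and it concerns configuration alone.

Compound 4 `COc1cc(C(c2ccc(O)c(OC)c2)[C@H](C)[C@@H](C)CO)ccc1O` is not yet measured. It differs from compound 1 as follows: 2-(hydroxymethyl)-1-methylpropyl in place of 2-(methoxymethyl)-1-methylpropyl on a saturated chain carbon bound to two aromatic carbons. Going by the values given here, no measured step covers this exchange. Compounds 1 and 2, which differ in more than one place, give numbers within the scatter of each other. No step beyond the scatter is therefore expected in this assay for compound 4; the expected step is a 1.1-fold lower number from compound 1 to compound 4 (0.05 log units; within the scatter). Compound 4 is estimated at 65000 nM, with a range from 28000 nM to 150000 nM.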

Compound 4, half-maximal inhibitory concentration: > 100000 nM
Compound 4: no number, only a limit (the forecaster's own chance of this, stated with the estimate: 30%); middle value at least 1.5-fold (0.18 log units) from the limit.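

In this assay, the exchange of 2-(methoxymethyl)-1-methylpropyl for 2-(hydroxymethyl)-1-methylpropyl on a saturated chain carbon bound to two aromatic carbons can now be read directly, as an at least 1.3-fold higher number from compound 1 to compound 4 (0.13 log units; that floor lies within the scatter). Compound 4 gives only a limit of the assay, > 100000 nM. The exchange therefore brings no measurable lowering of the number on this core, while the true size of the step stays unresolved, as it rests on: the limit of > 100000 nM in this assay, at which 2 of the 4 values shown sit.

As far as these compounds go, whether an amine or a carboxylic acid in place of the hydroxyl of 2-(hydroxymethyl)-1-methylpropyl would bring the number down remains open. Also open, from the compounds shown here alone, is whether the other drawn configuration of the chain would change the number on the core of compound 4.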